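The compounds below may be only part of what the source reports. "The series", "measured", "known", "first", "only" and "open" are said of these compounds alone.

Of the compounds shown here, three have been measured in a functional assay on the whole organism (strain Swiss albino) with Mus musculus as the target, in the maximal electroshock model, with a stated time of 2 h; on this read-out lower numbers stand for an effect already at smaller amounts and higher numbers for an effect only at larger amounts of compound.

Compound 1 `O=C1C(c2ccccc2)CC(c2ccccc2)C(=O)N1c1cccc(Cl)c1`: in this assay compound 1 reaches only the limit > 100 mg/kg, and that is a limit of the assay rather than a number.
Compound 2 `Cc1ccccc1N1C(=O)C(c2ccccc2)CC(c2ccccc2)C1=O`: in this assay compound 2 gives 21.5 mg/kg.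
Compound 3 `O=C1C(c2ccccc2Cl)CC(c2ccccc2Cl)C(=O)N1c1cccc(Cl)c1`: in this assay compound 3 gives 60.2 mg/kg.

From compound 1 to compound 2 the change is 2-methylphenyl in place of 3-chlorophenyl on an amide-type nitrogen in a ring. It brings an at least 4.6-fold lower number from compound 1 to compound 2 (0.66 log units; beyond the scatter), and the step can only be given as a lower bound because of the limit of > 100 mg/kg in this assay, at which 1 of the 3 values shown sits. Compound 3 carries a different core; how the core of compound 3 differs from that of compound 1 is not broken down here, and of the two numbers that are not limits compound 3 stands higher than compound 2.

Compound 4 `Cc1ccccc1N1C(=O)C(c2ccccc2Cl)CC(c2ccccc2Cl)C1=O` has not yet been measured. From compound 3 to compound 4 the change is 2-methylphenyl in place of 3-chlorophenyl on an amide-type nitrogen in a ring. It is the same kind of change as that from compound 1 to compound 2, but around the place the two differ: in compound 1 the two ring atoms each bear a phenyl group, in compound 3 each bears a 2-chlorophenyl group. For compound 4 a step of about a 4.0-fold lower number from compound 3 to compound 4 (0.60 log units; beyond the scatter) is expected, resting on the measured step of an at least 4.6-fold lower number from compound 1 to compound 2 (0.66 log units; beyond the scatter), with the caveat that its size is only a lower bound. Compound 4 is therefore estimated at 15 mg/kg, expected to fall between 6 mg/kg and 40 mg/kg.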

Compound 4, dose for half-maximal effect: 27.4 mg/kg
The estimate for compound 4 lay 1.8-fold (0.26 log units) below the measured number; the measured number falls inside the stated range.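

In this assay, 2-methylphenyl in place of 3-chlorophenyl on an amide-type nitrogen in a ring brings a 2.2-fold lower number from compound 3 to compound 4 (0.34 log units; beyond the scatter), so on the core whose two ring atoms each bear a 2-chlorophenyl group the number falls, as it also does on the core of compound 1, and the direction of the change holds on both cores shown. Set side by side, the two pairs read: the same change on two cores in this assay, an at least 4.6-fold lower number (0.66 log units; beyond the scatter) from compound 1 to compound 2 and a 2.2-fold lower number (0.34 log units; beyond the scatter) from compound 3 to compound 4; the limit leaves it open whether they differ. This does not show that the size of the step carries over from one core to the other, and two pairs are too few to support a general rule for the series, since compound 1 stands at a value that is a limit and not a number: the limit of > 100 mg/kg in this assay, at which 1 of the 4 values shown sits.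

The compounds shown leave open whether the same direction would hold on a core whose two ring atoms bear other groups, such as a methoxy-substituted phenyl or a pyridine ring. They also leave open how other groups on the ring nitrogen would compare with 2-methylphenyl and 3-chlorophenyl, for instance a benzyl group, a longer alkyl chain, or a phenyl ring carrying an amine or a carboxylic acid.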